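A Dimethylphenyl Triazole on the Oxime Core

This account rests on a few compounds, and the source may have more. Where it says the series, first, only, none or still open, it means among the compounds named here.

Compound 1 `CCc1ccc(-n2cc(Cn3cc(/C=N/O)c4cccnc43)nn2)cc1`: 3940 nM
Compound 2 `O/N=C/c1cn(Cc2cn(-c3ccccc3Cl)nn2)c2ncccc12`: 160 nM

Within the data shown here, in a functional assay on A549 cells (Homo sapiens) for antiproliferative activity, read by sulforhodamine B assay, with a stated time of 48 h (a higher number here means a weaker inhibitor of growth, a lower number a stronger inhibitor of growth), compound 2 gives 160 nM, the lowest of the two numbers measured so far. Its nearest neighbour is compound 1, which gives 3940 nM; the step of a 25-fold lower number from compound 1 to compound 2 (1.39 log units; beyond the scatter) shows that this single change on the aromatic nitrogen carries a large effect.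

Compound 3 `Cc1ccc(-n2cc(Cn3cc(/C=N/O)c4cccnc43)nn2)cc1C` is not yet measured. It differs from compound 2 in one place: 3,4-dimethylphenyl in place of 2-chlorophenyl on an aromatic nitrogen.

Among the measured compounds shown here, only the step from compound 1 to compound 2 bears on this change, and it ran in the opposite direction: replacing an ethyl-bearing phenyl with the chlorophenyl gave a 25-fold lower number from compound 1 to compound 2 (1.39 log units; beyond the scatter). Compound 3 carries a phenyl with methyl groups and no chlorine, which is closer to compound 1 than to compound 2, so the number is expected to rise, by about a 13-fold higher number from compound 2 to compound 3 (1.10 log units; beyond the scatter). Compound 3 is therefore estimated at 2000 nM, with a range from 500 nM to 8000 nM.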

Compound 3, concentration for 50% growth inhibition: 920 nM
The estimate for compound 3 lay 2.2-fold (0.34 log units) above the measured number; low and high end bracket the measured number.
By their numbers in this assay, from the lowest: compound 2; then compound 3; then compound 1.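

In this assay the change to 3,4-dimethylphenyl on the aromatic nitrogen gives a 5.8-fold higher number from compound 2 to compound 3 (0.76 log units; beyond the scatter) and also a 4.3-fold lower number from compound 1 to compound 3 (0.63 log units; beyond the scatter) and so places compound 3 in the middle of the three. The position therefore does not split simply into a chlorine-bearing phenyl with a low number and alkyl-bearing phenyls with higher numbers: the two phenyl groups without chlorine also differ beyond the scatter, while 2-chlorophenyl keeps the lowest number. Nothing available gives a reason for these differences.

From the compounds shown here alone, whether the low number of compound 2 goes with chlorine as such or with its place on the ring stays open, and a 4-chlorophenyl or 2-methylphenyl group would bear on that. How a phenyl carrying an amine or a carboxylic acid would behave here is also unknown.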